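The source may hold more compounds than are shown below. What is called first, only, known or untested is meant among the compounds shown, and "the series" means these compounds.

The measured compounds so far:
Compound 1 `Nc1ccccc1NC(=O)c1ccc(CSC(=S)N2CCN(c3ccc(Cl)cc3)CC2)cc1` gives 29% in a functional assay on A-375 cells (Homo sapiens) for antiproliferative activity, read by CCK-8 assay, with a stated time of 72 h, tested at 8 uM; on this read-out lower numbers stand for a weaker effect and higher numbers for a stronger effect at the one concentration tested.
Compound 2 `Nc1ccccc1NC(=O)c1ccc(CSC(=S)N2CCc3cc([N+](=O)[O-])ccc32)cc1` gives 29.5% in this assay.
Compound 3 `Nc1ccccc1NC(=O)c1ccc(CSC(=S)N2CCN(C(c3ccccc3)c3ccccc3)CC2)cc1` gives 8.4% in this assay.

Among these three numbers compound 1 stands second highest. Its nearest neighbour is compound 2, whose number lies a little higher but within the usual scatter, so the two cannot be set in any order. Its furthest neighbour is compound 3, whose number lies well below that of compound 1, beyond the scatter. All three share the same core and differ only in the group carried on the thiocarbamoyl nitrogen side of the molecule.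

The compound that has not yet been measured is compound 4 `Nc1ccccc1NC(=O)c1ccc(CSC(=S)N2CCN(c3ccncc3)CC2)cc1`. Compared with compound 1 the difference is pyridin-4-yl in place of 4-chlorophenyl on an amine nitrogen in a ring. Among the measured compounds shown here, no measured pair in this set isolates a change at this position, so the size of such a step cannot be read from the data. Given that compound 1 and compound 2 sit at about the same level with rather different groups there, the account expects the step of a number 4 percentage points lower from compound 1 to compound 4 (within the scatter) to stay within the scatter, with a slight lean downward.

Compound 4 is therefore estimated at 25% in this assay, in a range from 10% to 40%.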

Compound 4, a percentage reported as inhibition, at one concentration (the size of the read-out at that concentration, not a potency): 90.7%
Beside the measured number, compound 4's estimate is 65.7 percentage points below it, outside the stated range (above it).
By their numbers in this assay, from the lowest: compound 3; then compounds 1 and 2 (each within the scatter of the next); then compound 4.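

Among the compounds shown here, exchanging 4-chlorophenyl for pyridin-4-yl on an amine nitrogen in a ring gives a number 61.7 percentage points higher from compound 1 to compound 4 (beyond the scatter) in this assay and shows that this position can move the read-out by a large amount, which the earlier compounds could not show, as no two of them formed a pair differing in one place. The change is modest when counted: a six-membered aromatic ring stays in place, but the chlorine leaves, a ring nitrogen enters, and the group goes from no hydrogen-bond acceptor to one, so two alterations travel together in this single step. Nothing measured here explains the size of the step.

A plain phenyl group on the same nitrogen would separate the loss of the chlorine from the gain of the ring nitrogen, and pyridin-3-yl would ask whether the place of that nitrogen in the ring matters. The read-out also comes from one concentration, so it leaves open how compound 4 and compound 1 would compare as full potencies.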